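Shortening the amide chain: from 4-phenylbutyl to 3-fluorophenyl

The compounds below may be only part of what the source reports. "The series", "measured", "known", "first", "only" and "open" are said of these compounds alone.

Going by the values given here, compound 2 `O=C(CCCCc1ccccc1)Nc1ccc(N2CCN(c3ccc(OC[C@@H]4CO[C@@](Cn5cncn5)(c5ccc(Cl)cc5Cl)O4)cc3)CC2)cc1` gives the lower of the two numbers known so far in a functional assay on A549 cells (Homo sapiens) for inhibition, read by MTT assay, with a stated time of 48 h (a higher number here means a weaker inhibitor, a lower number a stronger inhibitor), at 2610 nM; compound 1 `CCCCC(=O)Nc1ccc(N2CCN(c3ccc(OC[C@@H]4CO[C@@](Cn5cncn5)(c5ccc(Cl)cc5Cl)O4)cc3)CC2)cc1` gives 5340 nM, and the step of a 2.0-fold lower number from compound 1 to compound 2 (0.31 log units; beyond the scatter) is modest but beyond the scatter. Compound 3 `O=C(Nc1ccc(N2CCN(c3ccc(OC[C@@H]4CO[C@@](Cn5cncn5)(c5ccc(Cl)cc5Cl)O4)cc3)CC2)cc1)c1cccc(F)c1` differs from compound 2 by 3-fluorophenyl in place of 4-phenylbutyl on a carbonyl carbon. Among the compounds with values here, no measured step covers this change directly; the only known step shows that adding a phenyl on the chain lowered the number modestly, whereas here the chain itself leaves. Compound 3 is therefore expected to fall near compound 2, with a step of a 1.3-fold higher number from compound 2 to compound 3 (0.13 log units; within the scatter) that may lie within the scatter. The estimate for compound 3 is 3500 nM, ranging from 1500 nM to 8500 nM.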

Compound 3, half-maximal inhibitory concentration: 6640 nM
Estimate against measurement, compound 3: 1.9-fold (0.28 log units) below, and the stated range covers the measured number.
By their numbers in this assay, from the lowest: compound 2; then compounds 1 and 3 (each within the scatter of the next).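

In this assay, 3-fluorophenyl on the carbonyl carbon does not keep the gain held by 4-phenylbutyl (a 2.5-fold higher number from compound 2 to compound 3 (0.41 log units; beyond the scatter)), so a phenyl ring in the group alone does not secure the lower number. Against butyl, the same group gives no separation (a 1.2-fold higher number from compound 1 to compound 3 (0.09 log units; within the scatter)), which places it level with the plain chain at this position. Nothing measured here accounts for these differences. The compounds shown leave open whether the chain length or the fluorine matters, since neither benzyl nor unsubstituted phenyl appears among them.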